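This account rests on a few compounds, and the source may have more. Where it says the series, first, only, none or still open, it means among the compounds named here.

Working notes on the series. Compound 1 `CC(C(=O)NCc1ccc(C(F)(F)F)nc1NCc1cccnc1)c1ccc(NS(C)(=O)=O)c(F)c1` is the reference point; in a functional assay on CHO-K1 cells for antagonist activity at transient receptor potential cation channel subfamily V member 1 (Homo sapiens), read by FLIPR (a lower number here means a stronger inhibitor, a higher number a weaker inhibitor), compound 1 is reported as "not active" (no number reported), so no single number stands for it. Two other members of the series carry a cyclic amine at the same position of the shared core: compound 2 `CC(C(=O)NCc1ccc(C(F)(F)F)nc1N1CCC(Cc2ccc(F)c(F)c2)CC1)c1ccc(NS(C)(=O)=O)c(F)c1` gives 30 nM in this assay, and compound 3 `CC(C(=O)NCc1ccc(C(F)(F)F)nc1N1CCC2(CC1)CC(c1ccccc1)=NO2)c1ccc(NS(C)(=O)=O)c(F)c1` gives 289 nM in this assay. Compound 4 `CC(C(=O)NCc1ccc(C(F)(F)F)nc1N1CCCCCCC1)c1ccc(NS(C)(=O)=O)c(F)c1` is not yet measured. Its change from compound 1: a group of 8 heavy atoms (7 carbon, 1 nitrogen; one eight-membered non-aromatic ring with 1 hetero atom) in place of a group of 8 heavy atoms (6 carbon, 2 nitrogen; one six-membered aromatic ring with 1 hetero atom), on an aromatic carbon. For the measured compounds named here, as compound 1 has no number, no step can be sized, but with compounds 2 and 3 both active the move to compound 4 is expected to bring a gain beyond the scatter. For compound 4 in this assay the estimate is 200 nM, within a range of 40 nM to 1500 nM.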

Compound 4, half-maximal inhibitory concentration: 27.8 nM
Compound 4: middle estimate off by 7.2-fold (0.86 log units), on the high side; measured number outside the range, below it.
By their numbers in this assay, from the lowest: compounds 4 and 2 (each within the scatter of the next); then compound 3.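

No step can be read from compound 1 to compound 4, since compound 1 stands as "not active" (no number reported) in this assay. No data shown bear on the cause of this result. The compounds shown leave open how the size of the non-aromatic ring relates to activity at this position.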